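An amino group on the ring of compound 2

A few compounds are considered here, and "the series" means these few. Any claim that something is new, unique, unknown or untested is made for them only; others in the source may bear on it.

Measured in a toxicity assay on MDCK cells (Canis lupus familiaris) for cytotoxicity, read by CCK-8 assay, with a stated time of 48 h; on this read-out higher numbers stand for lower toxicity in this test and lower numbers for higher toxicity in this test:
Compound 1 `O=C(NNc1c(Br)cccc1Br)c1ccc(-c2ccccc2)cc1`: 84100 nM
Compound 2 `O=C(NNc1c(Br)cccc1Br)c1ccc(B(O)O)cc1`: > 100000 nM, a limit

Compound 2 reads > 100000 nM in this assay, which is a limit of the assay and not a number. Compound 3 `Nc1ccc(C(=O)NNc2c(Br)cccc2Br)cc1` differs from compound 2 by one nitrogen atom in place of a group of 3 heavy atoms (1 boron, 2 oxygen; no ring), on an aromatic carbon. Here one nitrogen atom, as an amino group, takes the place of a group of 3 heavy atoms on an aromatic carbon, para to a large group. Among the compounds with values here, the one measured step that bears on this change, also made on an aromatic carbon, is an at least 1.1-fold higher number from compound 1 to compound 2 (0.07 log units; that floor lies within the scatter), so no step beyond the scatter is expected in this assay. The expected change is an at least 1.1-fold lower number from compound 2 to compound 3 (0.04 log units; that floor lies within the scatter). For compound 3 the estimated value is 90000 nM, with an expected range from 35000 nM to 150000 nM.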

Compound 3, half-maximal cytotoxic concentration: > 100000 nM
Compound 3 ended at the assay's limit (the forecaster's own chance of this, stated with the estimate: 45%); middle value at least 1.1-fold (0.04 log units) from the limit.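

In this assay compound 3 gives > 100000 nM, a limit of the assay and not a number. This shows that the position carries an amino group as well as the boron-bearing group without the value coming off that limit, and amino in place of phenyl on an aromatic carbon gives an at least 1.1-fold higher number from compound 1 to compound 3 (0.07 log units; that floor lies within the scatter). The step between the two compounds at the limit cannot be read because both values rest on the same limit: the limit of > 100000 nM in this assay, at which 2 of the 3 values shown sit.

Going by these compounds, what remains open is how far compound 2 and compound 3 lie beyond that limit, so the amino and boron-bearing groups cannot be ranked against each other in this assay. On these data alone, it is also open whether a carboxylic acid, a dimethylamino group or a longer chain on this aromatic carbon would give a value that can be read.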